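The source may report more compounds than this note shows. Statements on the series, on what has been measured and on what is new or still open speak of the compounds shown alone.

Of the compounds shown here, three have been measured in an ADME assay on Caco-2 cells (Homo sapiens) for permeability, in the apical to basolateral direction; a higher number here means that the compound crosses the layer faster, a lower number that the compound crosses the layer more slowly. Compound 1 (`Fc1ccc(Nc2ccc3c(C4CCNCC4)c[nH]c3c2)cc1F`) gives 7.1 10^-6 cm/s, compound 3 (`CN1CCC(c2c[nH]c3cc(Nc4ccc5c(C6CCN(C)CC6)c[nH]c5c4)ccc23)CC1`) gives 0.3 10^-6 cm/s, and compound 2 (`N#Cc1c[nH]c2nc(Nc3ccc4c(C5CCNCC5)c[nH]c4c3)ccc12`) gives 0.1 10^-6 cm/s, the lowest of the three numbers. Compound 3 is the nearest to compound 2, with a gap beyond the scatter, and compound 1 lies furthest away.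

Compound 4 (`c1cc2c(C3CCNCC3)c[nH]c2cc1Nc1ccc2c(C3CCNCC3)c[nH]c2n1`) has not yet been measured. It differs from compound 2 in one place, with piperidin-4-yl in place of cyano on an aromatic carbon. Within the data shown here, no step between measured compounds isolates this change, so the expectation rests on whole-molecule comparison. Compound 3 also carries a six-membered non-aromatic ring on each half of the molecule, and compound 3 stays low at 0.3 10^-6 cm/s. The step expected in this assay is small and upward, a 2.0-fold higher number from compound 2 to compound 4 (0.30 log units; within the scatter), and not beyond the scatter. For compound 4 the estimate is 0.2 10^-6 cm/s, with an expected range of 0.05 10^-6 cm/s to 0.8 10^-6 cm/s.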

Compound 4, apparent permeability in the Caco-2 assay: 0.4 10^-6 cm/s
Beside the measured number, compound 4's estimate is 2.0-fold (0.30 log units) below it; the range from low to high includes it.
By their numbers in the Caco-2 assay, from the lowest: compound 2; then compounds 3 and 4 (each within the scatter of the next); then compound 1.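

Among these compounds, in the Caco-2 assay, this is the first step that isolates a single place: on an aromatic carbon of the five-membered aromatic ring, two ring bonds from the ring nitrogen, piperidin-4-yl in place of cyano gives a 4.0-fold higher number from compound 2 to compound 4 (0.60 log units; beyond the scatter). In the Caco-2 assay, compound 2 gives 0.1 10^-6 cm/s and compound 4 gives 0.4 10^-6 cm/s. The position therefore accepts the six-membered non-aromatic ring without any loss in this read-out, and the step can now be read directly, not inferred from whole-molecule comparison. In a physicochemical assay for solubility, in phosphate buffer, at pH 7.4 (a lower number here means a less soluble compound, a higher number a more soluble compound), compound 2 gives 196000 nM and compound 4 gives 166000 nM. In the physicochemical assay, the same change gives a 1.2-fold lower number from compound 2 to compound 4 (0.07 log units; within the scatter), so it has no readable effect on solubility, and nothing available accounts for either result.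

Still open, on these data alone, is how a carboxylic acid or a dimethylaminomethyl group would behave on the same aromatic carbon. Also open, as far as these compounds go, is whether the step carries over to a different core, as it rests on one pair.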